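From trifluoromethyl to ethyl on the amide carbonyl

A few compounds are considered here, and "the series" means these few. Any claim that something is new, unique, unknown or untested is made for them only; others in the source may bear on it.

Measured so far in an ADME assay on microsomes (Homo sapiens) for metabolic stability; a higher number here means that the compound lasts longer, a lower number that the compound disappears faster:
Compound 1, `O=C(C1CCN(C(=O)C(F)(F)F)CC1)N1N=CCC1c1ccccc1`: compound 1 gives > 1.5 h, which is a limit of the assay.
Compound 2, `O=C(c1cnco1)N1CCC(C(=O)N2N=CC[C@H]2c2ccccc2)CC1`: compound 2 gives > 3 h, which is also a limit of the assay.
Compound 3, `N#Cc1cc(N2CCC(C(=O)N3N=CC[C@H]3c3cc(F)cc(F)c3)CC2)ncn1`: compound 3 gives 3.3 h.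

On the numbers shown, compound 1 stands only at a limit, namely (the limit of > 1.5 h in this assay, at which 1 of the 3 values shown sits), so its half-life is not known as a number. Compound 2 likewise sits at the limit of > 3 h in this assay, at which 1 of the 3 values shown sits. Compound 3 alone carries a measured number, and it lies in the same region as the two limits.

The step of interest goes to compound 4, `CCC(=O)N1CCC(C(=O)N2N=CCC2c2ccccc2)CC1`, which differs from compound 1 in one place: ethyl in place of trifluoromethyl on a carbonyl carbon. For the measured compounds named here, no pair of measured compounds in this set carries the same change, so the size of the step rests on expectation only. The step from compound 1 to compound 4 is estimated at an at least 1.2-fold lower number from compound 1 to compound 4 (0.09 log units; that floor lies within the scatter), a move downward that may stay within the usual scatter. Compound 4 is therefore expected to give about 1.2 h in this assay, with a range from 0.4 h to 3.5 h.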

Compound 4, half-life: > 2.75 h
Compound 4 ended at the assay's limit (the forecaster's own chance of this, stated with the estimate: 25%); middle value at least 2.2-fold (0.36 log units) away from the limit.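

In this assay compound 4 gives > 2.75 h, which is a limit of the assay. Compound 1 also stands at a limit, so no step can be read between compound 1 and compound 4. The compounds shown leave open whether ethyl in place of trifluoromethyl shifts the half-life at all, and by how much.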